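This account rests on a few compounds, and the source may have more. Where it says the series, first, only, none or still open, it means among the compounds named here.

Compound 2 `CCC(OC)C1=C(N2CC2)C(=O)C(C)=C(N2CC2)C1=O` stands lowest of the three compounds measured in a functional assay on L1210 cells (Mus musculus), with a stated time of 12 days (on this read-out lower numbers stand for lower potency and higher numbers for higher potency (the scale is a negative logarithm)), where compound 2 gives 5.68. Compound 1 `CC1=C(N2CC2)C(=O)C(C(C)COC(N)=O)=C(N2CC2)C1=O` gives 6.41 in this assay, and compound 3 `CC1=C(N2CC2)C(=O)C(N2CC2)=C(N2CC2)C1=O` gives 6.77. Both neighbours lie beyond the usual scatter above compound 2: the step of a number 0.73 log units lower from compound 1 to compound 2 (beyond the scatter), and the step of a number 1.09 log units higher from compound 2 to compound 3 (beyond the scatter).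

Compound 4 `CCC(COC(N)=O)C1=C(N2CC2)C(=O)C(C)=C(N2CC2)C1=O` has not yet been measured. Relative to compound 2 the change is (carbamoyloxy)methyl in place of methoxy on a saturated chain carbon bound to a double-bonded ring carbon and a saturated chain carbon. The side chain of compound 4 therefore carries a carbamate, as the side chain of compound 1 does, while the two aziridin-1-yl groups and the methyl on the shared core stay as in compound 2.

Within the data shown here, the step that bears most directly on this is the one from compound 1 to compound 2, in which a group of five heavy atoms without a carbamate replaced a group of seven heavy atoms that held one, and potency fell by a number 0.73 log units lower from compound 1 to compound 2 (beyond the scatter). Compound 4 reverses that kind of exchange, so a gain of similar size is expected, with compound 4 estimated at 6.3 in this assay, within a range of 5.8 to 6.8. That estimate means an expected step of a number 0.62 log units higher from compound 2 to compound 4 (beyond the scatter).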

Compound 4, logarithm of the reciprocal of the active concentration, log(1/C): 6.18
Compound 4: the middle estimate sits 0.12 log units above what was measured; low and high end bracket the measured number.
By their numbers in this assay, from the lowest: compound 2; then compounds 4 and 1 (each within the scatter of the next); then compound 3.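

On the saturated chain carbon bound to a double-bonded ring carbon and a saturated chain carbon, (carbamoyloxy)methyl in place of methoxy gives a number 0.50 log units higher from compound 2 to compound 4 (beyond the scatter) in this assay and ties the gain to this single change, something the earlier step between compound 1 and compound 2 could not do, since those side chains also differ in a methyl group. That methyl can now be read alone: methyl in place of hydrogen on a saturated chain carbon, two bonds along the chain from a double-bonded ring carbon, gives a number 0.23 log units lower from compound 1 to compound 4 (within the scatter) and leaves compound 1 and compound 4 indistinguishable on this read-out. There is no measurement that explains how the carbamate-bearing group raises the number, so only the size of the step is known.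

The compounds shown leave open whether the whole carbamate is required, or whether a chain ending in a free hydroxyl, an acetate ester or a urea would give the same number. They also leave open how a longer chain carrying the same carbamate would compare with compound 4.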